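The source may report more compounds than this note shows. Statements on the series, on what has been measured and on what is new or still open speak of the compounds shown alone.

Compound 1, with the structure `CN1CCN(c2ccc(Nc3ncc4nc(Nc5ccc(F)cc5)n([C@@H]5CCCNC5)c4n3)cc2)CC1`, is the starting point of this comparison. In a functional assay on HCC827 cells (Homo sapiens) for antiproliferative activity, read by MTT assay, with a stated time of 72 h (a higher number here means a weaker inhibitor, a lower number a stronger inhibitor), compound 1 gives 120 nM. For the measured compounds named here, only one other compound has been measured alongside it: compound 2, with the structure `CN1CCN(c2ccc(Nc3ncc4nc(Nc5ccc(F)cc5)n([C@@H]5CCCC(NC(=O)OC(C)(C)C)C5)c4n3)cc2)CC1`, which in this assay gives 280 nM. Compound 1 therefore stands at the lower of the two numbers, and the gap between them lies beyond the usual scatter of repeated measurements, so compound 2 is the weaker inhibitor of the pair.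

Compound 3, with the structure `CCOC(=O)CN1CC[C@H](n2c(Nc3ccc(F)cc3)nc3cnc(Nc4ccc(N5CCN(C)CC5)cc4)nc32)C1`, has not yet been measured. It differs from compound 1 in one place: 1-((ethoxycarbonyl)methyl)pyrrolidin-3-yl in place of piperidin-3-yl on an aromatic nitrogen. The shared core is otherwise untouched.

Going by the values given here, there is no measured pair that isolates this exact change, so the size of the step cannot be read off directly. Among the compounds with values here, the only guidance is that compound 2, the one other variation at hand, gives a higher number than compound 1. On that basis the step of a 2.5-fold higher number from compound 1 to compound 3 (0.40 log units; beyond the scatter) is expected to be a modest weakening, of the same order as the gap between compound 1 and compound 2. Compound 3 is thus estimated to give 300 nM, with a plausible range from 100 nM to 900 nM.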

Compound 3, half-maximal inhibitory concentration: 1810 nM
Estimate against measurement, compound 3: 6.0-fold (0.78 log units) below, outside the stated range (above it).
By their numbers in this assay, from the lowest: compound 1; then compound 2; then compound 3.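

On the aromatic nitrogen of the shared core, 1-((ethoxycarbonyl)methyl)pyrrolidin-3-yl in place of piperidin-3-yl gives a 15-fold higher number from compound 1 to compound 3 (1.18 log units; beyond the scatter) in this assay, a large step that shows this position is sensitive to the group it carries. The swap alters several things at once: the six-membered ring becomes a five-membered one, the (ethoxycarbonyl)methyl group appears on the ring nitrogen, and the hydrogen-bond donor of the piperidin-3-yl group is gone, since the entering group has none. Nothing measured here bears on the cause of this step, so the loss cannot be divided among those changes.

The compounds shown leave open whether ring size or the group on the ring nitrogen matters more: an unsubstituted pyrrolidin-3-yl group, or a piperidin-3-yl ring bearing the same (ethoxycarbonyl)methyl group, would pull the two apart. They also leave open how a smaller group such as methyl on that ring nitrogen, or a carboxylic acid in place of the ethyl ester, would read in this assay.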